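A few compounds are considered here, and "the series" means these few. Any claim that something is new, unique, unknown or untested is made for them only; others in the source may bear on it.

Measured so far:
- compound 1, `c1ccc(COc2ccccc2Nc2ncnc3cc4c(cc23)OCCOCCOCCO4)cc1`: 98400 nM
- compound 2, `FC(F)(F)c1ccc(COc2ccc(Nc3ncnc4cc5c(cc34)OCCOCCOCCO5)cc2)cc1`: > 100000 nM
- compound 3, `FC(F)(F)c1ccc(COc2cccc(Nc3ncnc4cc5c(cc34)OCCOCCOCCO5)c2)cc1`: 20000 nM

All three share the same core with a benzyloxy-substituted aniline attached to it. In a functional assay on SH-SY5Y cells (Homo sapiens) for antiproliferative activity, read by MTT assay, with a stated time of 72 h (on this read-out lower numbers stand for stronger inhibition and higher numbers for weaker inhibition), compound 3 gives 20000 nM, the lowest of the two numbers obtained; the nearest is compound 1 at 98400 nM, a gap that lies beyond the scatter of repeated measurements. For compound 2 this assay returns only a limit, > 100000 nM, not a number; this is the limit of > 100000 nM in this assay, at which 1 of the 3 values shown sits.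

Compound 4, `O=[N+]([O-])c1ccc(COc2cccc(Nc3ncnc4cc5c(cc34)OCCOCCOCCO5)c2)cc1`, is the next compound in this series and has not yet been measured in this assay. It differs from compound 3 in one place: nitro in place of trifluoromethyl on an aromatic carbon. Within the data shown here, no measured pair in this set shares that change, so the expected size of the step cannot be read from a measured step. With nothing to point the other way, the step from compound 3 to compound 4 in this assay is estimated as no change at the digits printed from compound 3 to compound 4 (within the scatter), meaning no change beyond the scatter.

On that basis compound 4 is expected to give about 20000 nM in this assay, with a range of 7000 nM to 60000 nM.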

Compound 4, half-maximal inhibitory concentration: > 100000 nM
Compound 4: a limit, no number (the forecaster's own chance of this, stated with the estimate: 10%); at least 5.0-fold (0.69 log units) between middle value and limit.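

Nitro in place of trifluoromethyl on this aromatic carbon, para to a large group, gives an at least 5.0-fold higher number from compound 3 to compound 4 (0.69 log units; beyond the scatter) in this assay. Among these compounds, this is the first step that isolates a single change at this place, and it shows that the substituent here is not interchangeable: going from 4-(trifluoromethyl)benzyl to 4-nitrobenzyl, with all else held constant, loses the measurable number seen for compound 3. Compound 4 returns a limit and not a number, so only the minimum size of the step can be read, and compound 4 joins compound 2 at that limit: the limit of > 100000 nM in this assay, at which 2 of the 4 values shown sit.

The pair gives no reading of why the two groups part, since a single change at this place cannot separate the contribution of the nitro group from that of losing the trifluoromethyl, and no other substituent at this carbon is available for comparison. Going by these compounds, whether a nitrile, a methoxy group, an amine or a simple chlorine on the same carbon would stay with compound 3 or fall to the limit with compound 4 remains open.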